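This account rests on a few compounds, and the source may have more. Where it says the series, first, only, none or still open, it means among the compounds named here.

In a functional assay on NCI-H460 cells (Homo sapiens) for inhibition, read by sulforhodamine B assay, with a stated time of 48 h (a lower number here means a stronger inhibitor of growth, a higher number a weaker inhibitor of growth), compound 1 `COC(=O)c1sc2cc(Nc3ccccc3Br)cnc2c1N` gives 30900 nM, the second highest of the three numbers measured. Compound 2 `COC(=O)c1sc2cc(Nc3ccc(F)cc3Br)cnc2c1N` gives 31300 nM, and the step from compound 1 to compound 2 is a 1.0-fold higher number from compound 1 to compound 2 (0.01 log units; within the scatter). Compound 3 `COC(=O)c1sc2cc(Nc3ccc4[nH]ccc4c3)cnc2c1N` gives 15800 nM, and the two values of compound 1 and compound 3 lie within the scatter of each other. Compound 4 `COC(=O)c1sc2cc(Nc3ncccn3)cnc2c1N` differs from compound 1 by pyrimidin-2-yl in place of 2-bromophenyl on a nitrogen on an aromatic ring. Going by the values given here, no measured step bears directly on this change; the only measured step, a 1.0-fold higher number from compound 1 to compound 2 (0.01 log units; within the scatter), is a small one within the scatter, and the values of compound 3 and compound 1 sit within the scatter as well. Compound 4 is therefore expected to show a step of a 1.1-fold higher number from compound 1 to compound 4 (0.05 log units; within the scatter), no change beyond the scatter. Compound 4 is estimated at 35000 nM, with a range from 12000 nM to 100000 nM.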

Compound 4, concentration for 50% growth inhibition: > 150000 nM
Compound 4: a limit, no number; the forecaster's own chance of this, stated with the estimate: 15%; middle value at least 4.2-fold (0.63 log units) away from the limit.
By their numbers in this assay, from the lowest: compounds 3, 1 and 2 (each within the scatter of the next). At a limit, above all of these: compound 4.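

Pyrimidin-2-yl in place of 2-bromophenyl on a nitrogen on an aromatic ring gives an at least 4.8-fold higher number from compound 1 to compound 4 (0.68 log units; beyond the scatter). In this assay compound 4 stands at > 150000 nM, which is a limit and not a number. This shows that the group at this place can shift the read-out beyond the scatter, which the fluoro step, a 1.0-fold higher number from compound 1 to compound 2 (0.01 log units; within the scatter), did not show.

The compounds shown do not separate the departure of the bromine from the arrival of the ring nitrogens. A plain phenyl or a pyridin-2-yl group on that nitrogen would bear on this.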